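Chloro to fluoro on the shared core of compound 2

The source may report more compounds than this note shows. Statements on the series, on what has been measured and on what is new or still open speak of the compounds shown alone.

Compound 2 `COc1cc(C(=O)NC2CCN(C)CC2)ccc1Nc1ncc(Cl)c(NC2CCCC2)n1` gives 2700 nM in a functional assay on HeLa cells (Homo sapiens) for cytotoxicity, read by MTT assay, with a stated time of 48 h (a lower number here means a stronger inhibitor, a higher number a weaker inhibitor), and stands at the high end of the two numbers in hand; its nearest neighbour is compound 1 `CN1CCC(NC(=O)c2ccc(Nc3ncc(Cl)c(NC4CCCC4)n3)cc2)CC1`, which gives 1500 nM in this assay, and the step of a 1.8-fold higher number from compound 1 to compound 2 (0.26 log units; within the scatter) lies within the scatter. Compound 3 `COc1cc(C(=O)NC2CCN(C)CC2)ccc1Nc1ncc(F)c(NC2CCCC2)n1` is not yet measured. It differs from compound 2 by fluoro in place of chloro on an aromatic carbon. Among the measured compounds shown here, no measured step touches that halogen: the single step in hand, a 1.8-fold higher number from compound 1 to compound 2 (0.26 log units; within the scatter), concerns the methoxy on a different ring and itself stays within the scatter, so it gives no direction for the present change. The expectation is therefore a step from compound 2 to compound 3 of a 1.1-fold higher number from compound 2 to compound 3 (0.05 log units; within the scatter), not beyond the scatter in either direction. Compound 3 is estimated at 3000 nM in this assay, with a range of 1200 nM to 7500 nM.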

Compound 3, half-maximal inhibitory concentration: 2200 nM
Estimate against measurement, compound 3: 1.4-fold (0.13 log units) above; low and high end bracket the measured number.
By their numbers in this assay, from the lowest: compounds 1, 3 and 2 (each within the scatter of the next).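

In this assay, among the compounds shown here, the step at the halogen is a 1.2-fold lower number from compound 2 to compound 3 (0.09 log units; within the scatter), the first reading at this position, which the methoxy step could not give. On this aromatic carbon, ortho to a cyclopentylamino group and para to a large group, chloro and fluoro therefore cannot be told apart in this assay, at least with the methoxy present on the other ring. No evidence is available on the compounds that bears on why the two halogens read alike.

The compounds shown leave open whether a methyl, a nitrile or a trifluoromethyl on this carbon would move the number beyond the scatter. Also open, on these data alone, is whether fluoro reads the same on the core of compound 1, and whether a longer chain in place of the cyclopentylamino group would alter the halogen step.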